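The source may hold more compounds than are shown below. What is called first, only, known or untested is meant among the compounds shown, and "the series" means these compounds.

In a functional assay on the whole organism with Mus musculus as the target (on this read-out lower numbers stand for an effect already at smaller amounts and higher numbers for an effect only at larger amounts of compound), compound 3 (`Cn1nc(-c2ccc(F)cc2)n(C)c1=S`) gives 0.61 mg/kg as its read-out. Compound 1 (`Cn1nc(-c2ccc(F)cc2F)n(C)c1=S`) gives 1 mg/kg as its read-out, and the two stand level, with a 1.6-fold lower number from compound 1 to compound 3 (0.21 log units; within the scatter) separating them. Compound 2 (`Cn1nc(-c2cccc(C(F)(F)F)c2)n(C)c1=S`), which bears a trifluoromethyl group, gives > 50 mg/kg and this is a limit, not a number. Compound 3 therefore sits level with compound 1 among the numbered results, and the third result lies at that limit.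

Compound 4 (`Cc1ccc(-c2nn(C)c(=S)n2C)cc1`) differs from compound 3 by methyl in place of fluoro on an aromatic carbon, para to a group of 8 heavy atoms (methyl in place of fluoro on an aromatic carbon) and nothing else. Among the measured compounds shown here, no measured step makes this exchange. The nearest one also removes a fluoro, but it puts hydrogen in its place, and it stays small at a 1.6-fold lower number from compound 1 to compound 3 (0.21 log units; within the scatter) for the pair. That step gives little guidance for a methyl, while compound 2 shows that a different group can leave the read-out at the limit of > 50 mg/kg in this assay, at which 1 of the 3 values shown sits, in this small set. A modest move towards a higher number is thus expected rather than a collapse, and the expected change is a 2.5-fold higher number from compound 3 to compound 4 (0.39 log units; beyond the scatter) in this assay on this reasoning. For compound 4 the estimate is 1.5 mg/kg with an expected range of 0.3 mg/kg to 10 mg/kg around it.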

Compound 4, dose for half-maximal effect: 1.74 mg/kg
Compound 4: the middle estimate sits 1.2-fold (0.06 log units) below what was measured; the range from low to high includes it.
By their numbers in this assay, from the lowest: compounds 3, 1 and 4 (each within the scatter of the next, the first and the last beyond it). At a limit, above all of these: compound 2.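

In this assay, the step for methyl in place of fluoro on an aromatic carbon, para to a group of 8 heavy atoms, is a 2.9-fold higher number from compound 3 to compound 4 (0.46 log units; beyond the scatter), and it is the first step shown that exchanges the group at this place. The earlier step removed a different fluoro and lay within the scatter, whereas this one lies beyond it, so the read-out does respond to what sits here, though only modestly, and compound 4 still gives a number rather than a limit. Compound 2 stays the only compound at a limit, which is no number: the limit of > 50 mg/kg in this assay, at which 1 of the 4 values shown sits.

How the read-out responds at this place to an amine, a carboxylic acid or a longer chain stays open, since methyl and fluoro are the only groups shown there. Also open, from the compounds shown here alone, is whether the same exchange of fluoro for methyl would give a step of similar size in the presence of the second fluoro that compound 1 carries.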